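Replacing the Amide Chain on a Shared Core

The source may report more compounds than this note shows. Statements on the series, on what has been measured and on what is new or still open speak of the compounds shown alone.

Of the compounds shown here, three with a shared core have been measured in a functional assay on the whole organism with Rattus norvegicus as the target; on this read-out lower numbers stand for an effect already at smaller amounts and higher numbers for an effect only at larger amounts of compound. Compound 1 `C[Si](C)(C)c1ccc2nc(N)sc2c1` gives 5 mg/kg in this assay. Compound 2 `CCCc1ccc2nc(N)sc2c1` gives 6 mg/kg in this assay. Among the compounds with values here, the single measured step between them, a 1.2-fold higher number from compound 1 to compound 2 (0.08 log units; within the scatter), concerns a group on an aromatic carbon and lies within the scatter. Compound 3 `N=c1sc2cc(OC(F)(F)F)ccc2n1CC(N)=O` gives 7 mg/kg in this assay and holds the highest of the three numbers, but its gaps to compound 2 and to compound 1 are both within the scatter, so the three compounds cannot be ordered.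

Compound 4 `CSCCCn1c(=N)sc2cc(OC(F)(F)F)ccc21` differs from compound 3 in one place: 2-(methylsulfanyl)ethyl in place of carbamoyl on a saturated chain carbon bound to an aromatic nitrogen. Within the data shown here, no measured step touches this position. Among the measured compounds shown here, the one step on record, a 1.2-fold higher number from compound 1 to compound 2 (0.08 log units; within the scatter), sits on an aromatic carbon and showed no movement beyond the scatter, which is at best a weak hint that the core tolerates change; it does not speak to the chain on the aromatic nitrogen. The expectation for compound 4 therefore rests on the value of compound 3 alone, with no step beyond the scatter foreseen in either direction. The expected step is no change at the digits printed from compound 3 to compound 4 (within the scatter). Compound 4 is estimated at 7 mg/kg, with a range from 3 mg/kg to 17 mg/kg.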

Compound 4, dose for half-maximal effect: 4.2 mg/kg
Compound 4: the middle estimate sits 1.7-fold (0.22 log units) above what was measured; measured number inside the range.
By their numbers in this assay, from the lowest: compounds 4, 1, 2 and 3 (each within the scatter of the next).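

The chain on the aromatic nitrogen had not been touched by any earlier step, and the exchange of carbamoylmethyl for 3-(methylsulfanyl)propyl now gives a 1.7-fold lower number from compound 3 to compound 4 (0.22 log units; within the scatter) in this assay. Within the data shown here, this is the first reading for this position, and it shows that, between these two compounds, carbamoyl with its hydrogen-bond donor can give way to 2-(methylsulfanyl)ethyl, which has no such donor, without a difference beyond the scatter, so the read-out here does not hang on the amide group. No measurement is at hand that would explain this result.

From the compounds shown here alone, what remains open is how far this tolerance extends, since a single pair speaks for the position and a primary amine or a carboxylic acid at the end of the chain, or a much longer chain, could read quite differently. Going by these compounds, it is equally open whether the sulfur in the chain matters at all, which a plain hydrocarbon chain in place of 3-(methylsulfanyl)propyl would show.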